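Bicyclic amide swap at the carbonyl, compound 3 expectation

The compounds below may be only part of what the source reports. "The series", "measured", "known", "first", "only" and "open" are said of these compounds alone.

Compound 2 `O=C(NCc1ccc(S(=O)(=O)c2ccccc2)cc1)c1nc2ccncc2s1` stands at the highest of the two numbers measured in an assay for inhibition of Nicotinamide phosphoribosyltransferase (Homo sapiens), read by mass spectrometry, with stated times of 15 min and 30 min (on this read-out higher numbers stand for weaker inhibition and lower numbers for stronger inhibition), compound 2 reading 210 nM, while compound 1 `O=C(NCc1ccc(S(=O)(=O)c2ccccc2)cc1)c1cc2ccncc2s1` reads 7 nM. Among the compounds with values here, the one measured step, a 30-fold higher number from compound 1 to compound 2 (1.48 log units; beyond the scatter), changes nothing but the bicyclic group on the carbonyl carbon, and it shows that this part of the series is sensitive to such exchanges. Compound 3 `O=C(NCc1ccc(S(=O)(=O)c2ccccc2)cc1)c1ccc2nccn2c1` carries a further change in the same place: a group of 9 heavy atoms (7 carbon, 2 nitrogen; one five-membered aromatic ring with 2 hetero atoms, one six-membered aromatic ring with 1 hetero atom) in place of a group of 9 heavy atoms (6 carbon, 2 nitrogen, 1 sulfur; one five-membered aromatic ring with 2 hetero atoms, one six-membered aromatic ring with 1 hetero atom), on a carbonyl carbon. Within the data shown here, no measured step covers this exact exchange; the step from compound 1 to compound 2 bears on it only in showing that the carbonyl-bound bicycle can move the number strongly. Among the measured compounds shown here, because the only comparable step, a 30-fold higher number from compound 1 to compound 2 (1.48 log units; beyond the scatter), was large, a shift beyond the scatter in this assay is expected, but its direction cannot be read from the two numbers, so the estimate is held near compound 2 with a wide range. Compound 3 is therefore expected to give 150 nM, between 15 nM and 1500 nM. The implied step, a 1.4-fold lower number from compound 2 to compound 3 (0.15 log units; within the scatter), is an estimate only.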

Compound 3, half-maximal inhibitory concentration: 18 nM
For compound 3 the middle estimate is 8.3-fold (0.92 log units) above the measured one; the range from low to high includes it.
By their numbers in this assay, from the lowest: compound 1; then compound 3; then compound 2.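

With three readings in this assay, the group on the carbonyl carbon no longer looks like a simple case of one exchange costing potency: the step back, a 12-fold lower number from compound 2 to compound 3 (1.07 log units; beyond the scatter), recovers most of what separated compound 2 from compound 1. Compounds 2 and 3 carry the same ring description, one five-membered aromatic ring with 2 hetero atoms and one six-membered aromatic ring with 1 hetero atom, yet they read far apart, so among these three compounds that description alone does not set the number, and sulfur in the group is not needed for a low one, since compound 3 has none. Compound 1 still keeps the lowest number, the remaining gap being a 2.6-fold higher number from compound 1 to compound 3 (0.41 log units; beyond the scatter), and nothing at hand explains this step or the one before it.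

As far as these compounds go, how a methyl group or an amine added to the bicycle would read remains open, as all three compounds carry unsubstituted groups at this place. From the compounds shown here alone, the rest of the molecule is identical throughout, so the response to a change there, such as an amine in place of the phenyl ring on the sulfonyl group, also stays unknown.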